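Iodo to methoxy on the carbamothioate aryl ring

A few compounds are considered here, and "the series" means these few. Any claim that something is new, unique, unknown or untested is made for them only; others in the source may bear on it.

Three S-carbamoyl cysteine derivatives have been tested in a functional assay on UACC-62 cells (Homo sapiens) for cytotoxicity, read by MTT assay, with a stated time of 6 days; a higher number here means a weaker inhibitor, a lower number a stronger inhibitor. Going by the values given here, compound 1 `CC(=O)N[C@@H](CSC(=O)Nc1ccc(I)cc1)C(=O)O` gives 46200 nM, and it is the only compound of the three for which a number, rather than a limit, is known. Compound 2 `CC(=O)N[C@@H](CSC(=O)Nc1cccc2ccccc12)C(=O)O` reaches only the limit of the assay, > 200000 nM. Compound 3 `CC(=O)N[C@@H](CSC(=O)Nc1ccc(C(F)(F)F)cc1[N+](=O)[O-])C(=O)O` likewise returns a limit, > 200000 nM. Compound 1 therefore stands alone on the numbers, with the other two sitting at the limit of > 200000 nM in this assay, at which 2 of the 3 values shown sit.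

Compound 4 `COc1ccc(NC(=O)SC[C@H](NC(C)=O)C(=O)O)cc1` has not yet been measured in this assay. It differs from compound 1 in one place: methoxy in place of iodo on an aromatic carbon. Among the compounds with values here, no pair of measured compounds differing in one place is available, so no measured step guides the expectation. Given that compound 1 already gives 46200 nM, any loss beyond the scatter would leave compound 4 a weak inhibitor as well. Compound 4 is expected to give about 110000 nM, with a range from 35000 nM to 250000 nM. The step of a 2.4-fold higher number from compound 1 to compound 4 (0.38 log units; beyond the scatter) is thus estimated as a modest weakening, possibly beyond the scatter.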

Compound 4, half-maximal inhibitory concentration: 75200 nM
Beside the measured number, compound 4's estimate is 1.5-fold (0.17 log units) above it; the range from low to high includes it.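

In this assay, methoxy in place of iodo on this aromatic carbon, para to a large group, gives a 1.6-fold higher number from compound 1 to compound 4 (0.21 log units; within the scatter), so the two groups cannot be told apart at this position. Going by these compounds alone, this is the first measured step here, and although methoxy brings a hydrogen-bond acceptor that iodo lacks, the change does not carry the reading beyond the scatter. Compound 2 and compound 3 remain limits rather than numbers: the limit of > 200000 nM in this assay, at which 2 of the 4 values shown sit.

On these data alone, whether an amine, a carboxylic acid or a longer alkoxy chain at this position would keep the reading in the same range remains open. As far as these compounds go, it also remains open whether any group here could give a clearly lower number than the two groups now compared.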